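Vero cytotoxicity across side-chain variants of one core

The source may hold more compounds than are shown below. What is called first, only, known or untested is meant among the compounds shown, and "the series" means these compounds.

Compound 2 `CCOC(=O)CN1CCN(c2c(F)cc3c(=O)c(C(=O)O)cn(C4CC4)c3c2OC)CC1C` carries an ethoxycarbonyl on a saturated chain carbon bound to an amine nitrogen in a ring. In an ADME assay on Vero cells (Chlorocebus sabaeus) for cytotoxicity, read by MTT assay, with a stated time of 72 h (on this read-out lower numbers stand for higher toxicity in this test and higher numbers for lower toxicity in this test), compound 2 gives 1000 ug/mL, the highest of the three numbers, although its gap to compound 1 `COc1c(N2CCN(CCC#N)C(C)C2)c(F)cc2c(=O)c(C(=O)O)cn(C3CC3)c12` is within the scatter: compound 1 gives 500 ug/mL, and a 2.0-fold higher number from compound 1 to compound 2 (0.30 log units; within the scatter). Compound 3 `CO/N=C(\C)CCN1CCN(c2c(F)cc3c(=O)c(C(=O)O)cn(C4CC4)c3c2OC)CC1C` sits at the other end; in this assay compound 3 gives 157 ug/mL, with a 6.4-fold lower number from compound 2 to compound 3 (0.80 log units; beyond the scatter) and a 3.2-fold lower number from compound 1 to compound 3 (0.50 log units; beyond the scatter).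

Compound 4 `COc1c(N2CCN(CC/C(C)=N/Nc3ccccc3)C(C)C2)c(F)cc2c(=O)c(C(=O)O)cn(C3CC3)c12` is not yet measured. Relative to compound 2 the change is a group of 11 heavy atoms (9 carbon, 2 nitrogen; one six-membered aromatic ring of carbon only) in place of a group of 5 heavy atoms (3 carbon, 2 oxygen; no ring), on a saturated chain carbon bound to an amine nitrogen in a ring. For the measured compounds named here, the step bearing most on it is the one from compound 2 to compound 3, where a larger group with a double bond outside aromatic rings replaced the ethoxycarbonyl and gave a 6.4-fold lower number from compound 2 to compound 3 (0.80 log units; beyond the scatter); the small swap from compound 1 to compound 2 stayed within the scatter. The entering group of compound 4 is larger again, so a step of roughly that size toward a lower number in this assay is expected, an 8.3-fold lower number from compound 2 to compound 4 (0.92 log units; beyond the scatter). Compound 4 is estimated at 120 ug/mL, with a range of 40 ug/mL to 350 ug/mL.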

Compound 4, half-maximal cytotoxic concentration: 62.5 ug/mL
The estimate for compound 4 lay 1.9-fold (0.28 log units) above the measured number; the measured number falls inside the stated range.
By their numbers in this assay, from the lowest: compound 4; then compound 3; then compounds 1 and 2 (each within the scatter of the next).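

In this assay, anilino in place of methoxy on a double-bonded nitrogen lowers the number further (a 2.5-fold lower number from compound 3 to compound 4 (0.40 log units; beyond the scatter)), so the group carried on that nitrogen still matters once the double bond is present. For the compounds shown here, compound 4 has the lowest number of the four, and its gap is the only large step in the set (a 16-fold lower number from compound 2 to compound 4 (1.20 log units; beyond the scatter)), while the step from the nitrile side chain is also beyond the scatter (an 8.0-fold lower number from compound 1 to compound 4 (0.90 log units; beyond the scatter)). No measurement on hand gives a reason for these steps.

Anilino brings both an aromatic ring and a hydrogen-bond donor, so the two remain unseparated here. Benzyloxy and methylamino on the double-bonded nitrogen would pull these features apart, and where those groups would fall relative to compound 3 and compound 4 remains open.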